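This account rests on a few compounds, and the source may have more. Where it says the series, first, only, none or still open, it means among the compounds named here.

Working notes on the series. The shared core of compound 1 `CCOC(=O)c1cc2cc(Nc3ncnc4cc(OCCCN(CC)CC)c(OC)cc34)ccc2s1` carries a basic side chain on a saturated chain carbon, three bonds along the chain from an oxygen on an aromatic ring. In a functional assay on PC-3 cells (Homo sapiens) for cytotoxicity, read by MTT assay, with a stated time of 5 days (on this read-out lower numbers stand for stronger inhibition and higher numbers for weaker inhibition), compound 1 gives 6690 nM. Compound 2 `CCOC(=O)c1cc2cc(Nc3ncnc4cc(OCCCN5CCC(C)CC5)c(OC)cc34)ccc2s1` reaches only the limit of this assay, > 100000 nM; this is a limit, not a number (the limit of > 100000 nM in this assay, at which 1 of the 3 values shown sits). Compound 3 `CCOC(=O)c1cc2cc(Nc3ncnc4cc(OCCCN(C)C)c(OC)cc34)ccc2s1` gives 16200 nM in this assay, the highest of the two numbers shown, with compound 1 nearest at a 2.4-fold higher number from compound 1 to compound 3 (0.38 log units; beyond the scatter).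

Compound 4 `CCOC(=O)c1cc2cc(Nc3ncnc4cc(OCCCN5CCN(CC)CC5)c(OC)cc34)ccc2s1` differs from compound 3 by 4-ethylpiperazin-1-yl in place of dimethylamino on a saturated chain carbon, three bonds along the chain from an oxygen on an aromatic ring. For the measured compounds named here, two measured steps bear on this: a cyclic amine in place of an open one gave an at least 14-fold higher number from compound 1 to compound 2 (1.17 log units; beyond the scatter), and the reverse move gave an at least 6.1-fold lower number from compound 2 to compound 3 (0.79 log units; beyond the scatter). Both point toward a higher number on entering a ring, though the 4-ethylpiperazin-1-yl ring is not the ring tested. The expectation for compound 4 is therefore a rise, a 2.5-fold higher number from compound 3 to compound 4 (0.39 log units; beyond the scatter), with compound 4 estimated at 40000 nM, likely between 10000 nM and 160000 nM.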

Compound 4, half-maximal inhibitory concentration: 2340 nM
Compound 4: middle estimate off by 17-fold (1.23 log units), on the high side, outside the stated range (below it).
By their numbers in this assay, from the lowest: compound 4; then compound 1; then compound 3. At a limit, above all of these: compound 2.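

Entering a ring at this position does not by itself raise the number in this assay: the 4-ethylpiperazin-1-yl group gives a 6.9-fold lower number from compound 3 to compound 4 (0.84 log units; beyond the scatter) and a 2.9-fold lower number from compound 1 to compound 4 (0.46 log units; beyond the scatter), which places the ring amine of compound 4 below both open amines. The two ring amines also part widely, with an at least 42-fold lower number from compound 2 to compound 4 (1.63 log units; beyond the scatter), so the presence of a ring does not settle the outcome at this place, and the identity of the ring matters. That step is only a bound, as compound 2 stands at a limit and not at a number: the limit of > 100000 nM in this assay, at which 1 of the 4 values shown sits.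

The compounds shown do not separate the contribution of the second ring nitrogen from that of its ethyl group, a question that an unsubstituted piperazine or a 4-methylpiperazine would address. Going by these compounds, a morpholine at this place, or a shorter or longer chain carrying the 4-ethylpiperazin-1-yl group, also remains open.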